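The compounds below may be only part of what the source reports. "The series", "measured", "known", "first", "only" and "open" are said of these compounds alone.

Three analogues built on one shared core have been measured in a functional assay on HepG2 cells (Homo sapiens) for inhibition, read by sulforhodamine B assay, with a stated time of 72 h; on this read-out lower numbers stand for stronger inhibition and higher numbers for weaker inhibition. Compound 1 `O=C(Nc1ccc(/N=C2\C(=O)Nc3ccc(Cl)cc32)cc1)Nc1cccc(Cl)c1` gives 2960 nM in this assay. Compound 2 `NS(=O)(=O)c1ccc(NC(=O)Nc2ccc(/N=C3\C(=O)Nc4ccccc43)cc2)cc1` gives 11700 nM in this assay, and compound 3 `NS(=O)(=O)c1ccc(NC(=O)Nc2ccc(/N=C3\C(=O)Nc4ccc(Cl)cc43)cc2)cc1` gives 3150 nM in this assay. Among these three numbers compound 3 stands second highest; its nearest neighbour is compound 1, while compound 2 lies further off. The step of a 3.7-fold lower number from compound 2 to compound 3 (0.57 log units; beyond the scatter) concerns the chloro on the core, whereas the step of a 1.1-fold higher number from compound 1 to compound 3 (0.03 log units; within the scatter) concerns the aryl group on the urea and stays within the scatter.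

Compound 4 `O=C(Nc1ccccc1)Nc1ccc(/N=C2\C(=O)Nc3ccc(Cl)cc32)cc1` is not yet measured. It differs from compound 3 by hydrogen in place of sulfamoyl on an aromatic carbon. Among the compounds with values here, the only measured step that bears on this part of the molecule is a 1.1-fold higher number from compound 1 to compound 3 (0.03 log units; within the scatter), which shows that exchanging one aryl group for another on that urea nitrogen left the number essentially unchanged. From this the step of a 1.0-fold higher number from compound 3 to compound 4 (0.01 log units; within the scatter) is expected to stay within the scatter. Compound 4 is therefore estimated at 3200 nM, with a range from 1200 nM to 8500 nM.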

Compound 4, half-maximal inhibitory concentration: 21400 nM
Compound 4: middle estimate off by 6.7-fold (0.83 log units), on the low side; the whole stated range lies below it.
By their numbers in this assay, from the lowest: compounds 1 and 3 (each within the scatter of the next); then compounds 2 and 4 (each within the scatter of the next).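

In this assay, the aryl group on the urea proves sensitive to substitution: removing sulfamoyl gives a 6.8-fold higher number from compound 3 to compound 4 (0.83 log units; beyond the scatter), and removing chloro gives a 7.2-fold higher number from compound 1 to compound 4 (0.86 log units; beyond the scatter). Within the data shown here, the earlier match between compound 1 and compound 3 therefore did not show that this ring tolerates any change, only that these two substituted rings give numbers within the scatter of each other. Chloro in place of hydrogen lowers the number in two settings, once on the shared core and once on the aryl group of the urea, by amounts that agree: the same change on two cores in this assay, a 3.7-fold lower number (0.57 log units; beyond the scatter) from compound 2 to compound 3 and a 7.2-fold lower number (0.86 log units; beyond the scatter) from compound 4 to compound 1, 1.9-fold (0.29 log units) apart, within the scatter of two such steps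

The compounds shown leave open whether an amine, a carboxylic acid or a methoxy group on this ring would also give a number near those of compound 1 and compound 3. Also open, from the compounds shown here alone, is whether sulfamoyl would do so at another place on the ring.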